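Aryl Sulfonamides Versus an Isoxazole: Estimating Compound 4

The source may hold more compounds than are shown below. What is called first, only, known or untested is meant among the compounds shown, and "the series" means these compounds.

Measured so far:
compound 1, `Cc1noc(C)c1S(=O)(=O)N1CCC(N2CCC(C)CC2)CC1`: > 5000 nM
compound 2, `CC1CCN(C2CCN(S(=O)(=O)c3ccc(OCc4ccccc4)cc3)CC2)CC1`: 385 nM
compound 3, `CC1CCN(C2CCN(S(=O)(=O)c3cc(F)c(Br)c(F)c3)CC2)CC1`: 107 nM

Three compounds sharing one core have been examined in a functional assay on DLD-1 cells (Homo sapiens) for antiproliferative activity, read by CellTiter-Glo, with a stated time of 72 h; a higher number here means a weaker inhibitor, a lower number a stronger inhibitor. Compound 1 stands apart from the other two. In this assay compound 1 gives > 5000 nM, which is a limit of the assay and not a number. This is recorded as the limit of > 5000 nM in this assay, at which 1 of the 3 values shown sits. Compound 2 carries a benzyloxyphenyl group on the sulfonyl sulfur, and in this assay compound 2 gives 385 nM. Compound 3 carries a bromodifluorophenyl group in the same place, and in this assay compound 3 gives 107 nM. Within the data shown here, no single-point step between measured compounds is available, so the two numbers for compound 2 and compound 3 are simply what they show: both lie well inside the measurable range.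

Compound 4, `CC1CCN(C2CCN(S(=O)(=O)c3cncc(Br)c3)CC2)CC1`, has not yet been measured. It differs from compound 1 in one place: 5-bromopyridin-3-yl in place of 3,5-dimethyl-1,2-oxazol-4-yl on a sulfonyl sulfur. With a six-membered aromatic ring on the sulfonyl sulfur, compound 4 resembles compound 2 and compound 3 more than compound 1. For compound 4 the expected step is an at least 12-fold lower number from compound 1 to compound 4 (1.09 log units; beyond the scatter), toward stronger inhibition and beyond the usual scatter. Compound 4 is therefore estimated at 400 nM, in a range from 100 nM to 2500 nM.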

Compound 4, half-maximal inhibitory concentration: > 5000 nM
Compound 4: no number, only a limit; the forecaster's own chance of this, stated with the estimate: 15%; middle value at least 12-fold (1.09 log units) away from the limit.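

In this assay, among these compounds, compound 4 gives > 5000 nM, which is a limit of the assay and not a number, and compound 1 also stands at a limit, so no step between compound 1 and compound 4 can be read: the limit of > 5000 nM in this assay, at which 2 of the 4 values shown sit.

The compounds shown leave open whether 5-bromopyridin-3-yl in place of 3,5-dimethyl-1,2-oxazol-4-yl on the sulfonyl sulfur changes the inhibition at all.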